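The compounds below may be only part of what the source reports. "The series", "measured", "known", "first", "only" and "open" are said of these compounds alone.

Measured so far in a functional assay on SW480 cells (Homo sapiens) for cytotoxicity, read by MTT assay, with a stated time of 24 h; a higher number here means a weaker inhibitor, a lower number a stronger inhibitor:
compound 1, `C=CC1=C(C(=O)Nc2ccc(C)cc2)C(c2ccc(F)cc2)OC1`: > 100000 nM, which is a limit of the assay rather than a number
compound 2, `C=CC1=C(C(=O)Nc2ccc(C)cc2)C(c2ccc(OC)cc2)OC1`: > 100000 nM, likewise a limit of the assay
compound 3, `C=CC1=C(C(=O)NCCC)C(c2ccc(OC)cc2)OC1`: > 100000 nM, again a limit of the assay

Compound 1 therefore stands only at a limit in this assay, with no number of its own. Neither measured step can be read, a step that the two limits leave unreadable from compound 1 to compound 2 and a step that the two limits leave unreadable from compound 2 to compound 3, because of the limit of > 100000 nM in this assay, at which 3 of the 3 values shown sit. Compound 4, `C=CC1=C(C(=O)NCc2ccccc2)C(c2ccc(F)cc2)OC1`, has not yet been measured in this assay. It differs from compound 1 in one place: benzyl in place of 4-methylphenyl on an amide-type nitrogen. Among the measured compounds shown here, the only measured step at the same amide-type nitrogen, a step that the two limits leave unreadable from compound 2 to compound 3, ran from one limit to another and so gives no size to lean on. With no readable step in hand, no shift beyond the scatter can be argued for either direction. Compound 4 is expected to come out near the same limit, estimated at 100000 nM with a range from 50000 nM to 300000 nM. That estimate means an expected step of a number no higher from compound 1 to compound 4 (the limit leaves the size open).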

Compound 4, half-maximal inhibitory concentration: > 100000 nM
Compound 4: only a limit was reported (the forecaster's own chance of this, stated with the estimate: 75%); the middle value sits exactly at the limit.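

No step can be read from compound 1 to compound 4 in this assay, because each compound stands only at a limit: the limit of > 100000 nM in this assay, at which 4 of the 4 values shown sit. The compounds shown leave open whether benzyl, propyl or 4-methylphenyl on the amide-type nitrogen makes any difference to cytotoxicity in this assay.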